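Urea replacing amide in an aryl sulfonate series

The source may report more compounds than this note shows. Statements on the series, on what has been measured and on what is new or still open speak of the compounds shown alone.

Compound 1 `CC(=O)Nc1cccc(S(=O)(=O)Oc2ccccc2C(C)C)c1` gives 21000 nM in a functional assay on HT-1080 cells (Homo sapiens) for antiproliferative activity, read by sulforhodamine B assay, with a stated time of 48 h; on this read-out higher numbers stand for weaker inhibition and lower numbers for stronger inhibition. Compound 2 `CC(C)C(=O)Nc1ccc(S(=O)(=O)Oc2ccccc2C(C)C)cc1` gives 4900 nM. Compound 3 `CC(C)C(=O)Nc1ccc(S(=O)(=O)Oc2ccccc2I)cc1` gives 3300 nM.

Compound 3 has the lowest number of the three; the step of a 1.5-fold lower number from compound 2 to compound 3 (0.17 log units; within the scatter) is within the scatter, while compound 1 sits well beyond it. Compound 4 `CCCNC(=O)Nc1ccc(S(=O)(=O)Oc2ccccc2I)cc1` differs from compound 3 by propylamino in place of isopropyl on a carbonyl carbon. For the measured compounds named here, no measured step touches this carbonyl carbon: the only single-point step, from compound 2 to compound 3, changes the aromatic substituent, and compound 1 differs from compound 2 in more than one place. Compound 4 is therefore expected to stay close to compound 3, with a 1.4-fold higher number from compound 3 to compound 4 (0.13 log units; within the scatter) likely within the scatter. Compound 4 is estimated at 4500 nM, within 1300 nM to 15000 nM.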

Compound 4, half-maximal inhibitory concentration: 700 nM
Estimate against measurement, compound 4: 6.4-fold (0.81 log units) above; measured number below the stated range.
By their numbers in this assay, from the lowest: compound 4; then compounds 3 and 2 (each within the scatter of the next); then compound 1.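

Up to this point, the only single-point step had changed the aromatic substituent and stayed within the scatter. In this assay, propylamino in place of isopropyl on the carbonyl carbon gives a change beyond the scatter (a 4.7-fold lower number from compound 3 to compound 4 (0.67 log units; beyond the scatter)), so this carbonyl carbon responds where the aromatic substituent step did not. The entering group brings a nitrogen and a hydrogen-bond donor, but no measurement available here accounts for the lower number. As far as these compounds go, it remains open whether butylamino or dimethylamino on this carbonyl carbon would behave like propylamino. From the compounds shown here alone, it also remains open whether propylamino gives a similar step with isopropyl in place of iodo on the aromatic carbon.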